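The source may hold more compounds than are shown below. What is called first, only, known or untested is meant among the compounds shown, and "the series" means these compounds.

Measured compounds:
Compound 1, `C=CCOc1cc(C2=C(c3cc(OC)c(OC)c(OC)c3)C(=O)C(O)C2)ccc1OC`, gives > 100 ug/mL in an ADME assay on HEK293 cells (Homo sapiens) for cytotoxicity, read by MTT assay, with a stated time of 72 h; a higher number here means a weaker inhibitor, a lower number a stronger inhibitor; this value is a limit of the assay, not a number.
Compound 2, `COc1ccc(C2=C(c3cc(OC)c(OC)c(OC)c3)C(=O)C(O)C2)cc1`, gives 6.3 ug/mL.

For the measured compounds named here, compound 2 is the only compound here with a number. The other value, that of compound 1, is only a limit: the limit of > 100 ug/mL in this assay, at which 1 of the 2 values shown sits. Compound 3, `COc1ccc(C2=C(c3cc(OC)c(OC)c(OC)c3)C(=O)C(O)C2)cc1NC(=O)c1ccccc1`, is made from compound 2 by a single change: benzamido in place of hydrogen on an aromatic carbon. Going by the values given here, one measured step bears on this ring: an at least 15-fold lower number from compound 1 to compound 2 (1.20 log units; beyond the scatter), in which a group on the same ring was taken away and the number fell by a large amount. Among the compounds with values here, putting a group back onto that ring, here the much larger benzamido group, is therefore expected to push the number the other way, though the size of the new group leaves the amount uncertain, and the only measured comparison involves a limit rather than a number. The expected step is a 4.8-fold higher number from compound 2 to compound 3 (0.68 log units; beyond the scatter). Compound 3 is estimated at 30 ug/mL, with a likely range from 8 ug/mL to 100 ug/mL.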

Compound 3, half-maximal inhibitory concentration: > 100 ug/mL
Compound 3: a limit, no number (the forecaster's own chance of this, stated with the estimate: 30%); middle value at least 3.3-fold (0.52 log units) from the limit.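

Putting benzamido in place of hydrogen on this aromatic carbon, ortho to a methoxy group, gives an at least 15-fold higher number from compound 2 to compound 3 (1.20 log units; beyond the scatter) in this assay. The value of compound 3, > 100 ug/mL, is a limit of the assay and not a number. So this place on the ring has now been tested with two different groups, allyloxy in compound 1 and benzamido in compound 3, and both give a much weaker effect on these cells than hydrogen in compound 2, although the step from compound 1 to compound 3 cannot be read because both compounds end at the same ceiling: the limit of > 100 ug/mL in this assay, at which 2 of the 3 values shown sit.

As far as these compounds go, with only hydrogen giving a number here, it remains open whether a smaller group at this place, such as a fluorine atom, a hydroxyl or an amine, would keep a number close to that of compound 2 or would also reach the limit. How far compound 1 and compound 3 lie beyond the limit is also unknown, so allyloxy and benzamido cannot be ranked against each other.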